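From 2-methylbenzyl to 3-methylbenzyl: working notes

This account rests on a few compounds, and the source may have more. Where it says the series, first, only, none or still open, it means among the compounds named here.

- compound 1 `Cc1n[nH]c2c1[C@@H](c1ccc(OCc3ccc(F)cc3)cc1)S[C@@H](C)C(=O)N2`: "not determined" (no result reported)
- compound 2 `Cc1ccccc1COc1ccc([C@H]2S[C@@H](C)C(=O)Nc3[nH]nc(C)c32)cc1`: 111000 nM

Going by the values given here, in an ADME assay on L929 cells (Mus musculus) for cytotoxicity, read by microscopy, with a stated time of 96 h (on this read-out higher numbers stand for lower toxicity in this test and lower numbers for higher toxicity in this test), compound 2 gives 111000 nM as the only number available, so it cannot yet be ranked against another compound. Compound 3 `Cc1cccc(COc2ccc([C@H]3S[C@@H](C)C(=O)Nc4[nH]nc(C)c43)cc2)c1` differs from compound 2 as follows: 3-methylphenyl in place of 2-methylphenyl on a saturated chain carbon bound to an oxygen on an aromatic ring with 3-methylphenyl in place of 2-methylphenyl on a saturated chain carbon bound to an oxygen on an aromatic ring. Among the compounds with values here, no measured step in this assay shows what such a change does, and no direction is expected. The expected step of a 1.1-fold lower number from compound 2 to compound 3 (0.05 log units; within the scatter) stays within the usual scatter of the measurement. Compound 3 is estimated at 100000 nM with an expected range from 45000 nM to 220000 nM on this read-out.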

Compound 3, concentration lethal to 50% of the cells: 98900 nM
The estimate for compound 3 lay 1.0-fold (0.00 log units) above the measured number; low and high end bracket the measured number.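

In this assay, going by these compounds alone, 3-methylphenyl in place of 2-methylphenyl on a saturated chain carbon bound to an oxygen on an aromatic ring gives a 1.1-fold lower number from compound 2 to compound 3 (0.05 log units; within the scatter), the only measured step at this position. In this test, the two methylphenyl groups therefore cannot be told apart. Nothing measured here offers an explanation for this result.

Compound 1 gives "not determined" (no result reported), so its fluorine-bearing group cannot be compared. On these data alone, whether an amine or a carboxylic acid in place of the methyl group would move the number beyond the scatter remains open.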